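Cyclopentyl in place of isopentyl: notes on compound 3

The source may hold more compounds than are shown below. What is called first, only, known or untested is meant among the compounds shown, and "the series" means these compounds.

In an ADME assay on the whole organism (plasma, Homo sapiens) for protein binding, read by LC-MS, with a stated time of 24 h (on this read-out higher numbers stand for a larger free fraction and lower numbers for a smaller free fraction), compound 1 `Cc1noc(-c2ccc(O[C@H]3CCC[C@H](C(=O)O)C3)cc2)c1COC(=O)N(C)CCC(C)C` gives 0.003. Compound 2 `Cc1nc(-c2nnn(C)c2COC(=O)N(C)CC2CCC2)ccc1O[C@H]1CCC[C@H](C(=O)O)C1` gives 0.033. The gap between the two lies beyond the scatter and leaves compound 1 with the lower number. These two compounds differ in more than one place, so their gap says nothing about a single change.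

Compound 3 `Cc1noc(-c2ccc(O[C@H]3CCC[C@H](C(=O)O)C3)cc2)c1COC(=O)N(C)C1CCCC1` keeps the core of compound 1 and carries cyclopentyl in place of isopentyl on an amide-type nitrogen. For the measured compounds named here, no measured pair isolates a change of this kind, so the expectation rests on the structures alone. In this assay, no shift beyond the scatter is expected. The expected step is a 1.3-fold higher number from compound 1 to compound 3 (0.12 log units; within the scatter), a small one towards a larger free fraction. For compound 3 the estimated value is 0.004, with an expected range of 0.002 to 0.008.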

Compound 3, unbound fraction: 0.004
For compound 3 middle estimate and measured number coincide at the digits printed, and the stated range covers the measured number.
By their numbers in this assay, from the lowest: compounds 1 and 3 (each within the scatter of the next); then compound 2.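

At this position on the amide-type nitrogen, the series now has its first single-place comparison: in this assay, cyclopentyl in place of isopentyl gives a 1.3-fold higher number from compound 1 to compound 3 (0.12 log units; within the scatter), so this read-out does not separate the open chain from the five-membered ring of carbon only. Both groups carry the same count of heavy atoms and no hydrogen-bond donors or acceptors, and the free fraction of compound 3 stays within the scatter of that of compound 1. No measurement at hand accounts for this outcome.

Going by these compounds, whether the position stays this insensitive with a different kind of group, such as a longer chain, an amine or a carboxylic acid on the same nitrogen, remains open. Also open, on these data alone, is whether the same exchange would read alike on the core of compound 2.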